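The source may report more compounds than this note shows. Statements on the series, on what has been measured and on what is new or still open speak of the compounds shown alone.

Measured so far in a functional assay on KB cells (Homo sapiens) for antiproliferative activity, read by sulforhodamine B assay, with a stated time of 3 days; on this read-out lower numbers stand for an effect already at smaller amounts and higher numbers for an effect only at larger amounts of compound:
- compound 1 `CCCOC1=C(CCC)C(=O)/C(=C(O)/C=C/c2ccccc2)C(=O)C1(CCC)CCC`: 2.7 uM
- compound 2 `COC1=C(CC(C)C)C(=O)/C(=C(O)/C=C/c2ccccc2)C(=O)C1(CC(C)C)CC(C)C`: 7.9 uM
- compound 3 `COC1=C(CCC(C)C)C(=O)/C(=C(O)/C=C/c2ccccc2)C(=O)C1(CCC(C)C)CCC(C)C`: 17.5 uM

Compound 1 has the lowest number of the three, with compound 2 nearest and compound 3 furthest; both gaps lie beyond the usual scatter. Compound 4 `CCCC1=C(OC)C(CCC)(CCC)C(=O)/C(=C(O)\C=C\c2ccccc2)C1=O` is not yet measured. It differs from compound 1 in one place: hydrogen in place of ethyl on a saturated chain carbon bound to an oxygen on an unsaturated carbon. For the measured compounds named here, no pair of measured compounds shows this same change on its own, so its effect in this assay is not known from the series. Compounds 2 and 3 also carry methoxy, but their other chains differ as well, so they do not isolate this step. Expectation: a small step, if any, probably toward a somewhat higher number, within or near the scatter, so that compound 4 is estimated at 3.5 uM (range 1.5 uM to 8 uM), an expected step of a 1.3-fold higher number from compound 1 to compound 4 (0.11 log units; within the scatter).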

Compound 4, concentration for half-maximal effect: 4.6 uM
The estimate for compound 4 lay 1.3-fold (0.12 log units) below the measured number; low and high end bracket the measured number.
By their numbers in this assay, from the lowest: compounds 1, 4 and 2 (each within the scatter of the next, the first and the last beyond it); then compound 3.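

In this assay, for the compounds shown here, the change from propoxy to methoxy on the core of compound 1 gives a 1.7-fold higher number from compound 1 to compound 4 (0.23 log units; within the scatter) and is the first reading of this change on its own. With the propyl chains held constant, the two compounds cannot be told apart at this position, so the full propoxy group is not needed to stay within the scatter of compound 1. No measurement available here accounts for the step.

As far as these compounds go, whether a longer chain on this oxygen would stay within the scatter remains open. So does the effect of an amine or a carboxylic acid at the end of this chain.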